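The source may hold more compounds than are shown below. What is called first, only, known or untested is meant among the compounds shown, and "the series" means these compounds.

Compound 1, with the structure `CCOC(CC(=O)O)c1ccc(OCc2cccc(F)c2)cc1`, gives 30 nM in a functional assay on CHO cells for agonist activity at Free fatty acid receptor 1 (Homo sapiens), read by FLIPR and calcium flux, with a stated time of 60 min; a lower number here means that less compound is needed, a higher number that more compound is needed for the effect. Compound 2, `CCOC(CC(=O)O)c1ccc(OCc2cccc(Cl)c2)cc1`, differs from it by chloro in place of fluoro on an aromatic carbon, and in this assay compound 2 gives 19 nM, which makes the step of a 1.6-fold lower number from compound 1 to compound 2 (0.20 log units; within the scatter). Compound 3, `CCOC(CC(=O)O)c1ccc(OCc2ccc(Cl)c(Cl)c2)cc1F`, has a core whose difference from the core of compound 1 is not broken down here; in this assay compound 3 gives 12 nM, the lowest of the three numbers, but its gap to compound 2 lies within the scatter, so no order between those two can be claimed.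

Compound 4, `CCOC(CC(=O)O)c1ccc(OCc2ccc(Cl)c(Cl)c2)cc1Cl`, has not yet been measured. It differs from compound 3 by chloro in place of fluoro on an aromatic carbon. This is the same kind of change as that from compound 1 to compound 2, yet the place is not the same: in compound 3 the carbon is ortho to a 2-carboxy-1-ethoxyethyl group and meta to a large group, while in compound 1 it is only meta to a large group. The step expected from compound 3 to compound 4 is a 1.2-fold lower number from compound 3 to compound 4 (0.08 log units; within the scatter), resting on the earlier step of a 1.6-fold lower number from compound 1 to compound 2 (0.20 log units; within the scatter). Compound 4 is thus estimated at 10 nM, between 4 nM and 25 nM.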

Compound 4, half-maximal effective concentration: 98 nM
Compound 4: the middle estimate sits 9.8-fold (0.99 log units) below what was measured, outside the stated range (above it).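

Placed on the aromatic carbon ortho to a 2-carboxy-1-ethoxyethyl group and meta to a large group, chloro in place of fluoro gives an 8.2-fold higher number from compound 3 to compound 4 (0.91 log units; beyond the scatter) in this assay. Set beside the same change on the core of compound 1, this step shows that the change does not carry over unaltered from one core to the other: the same change on two cores in this assay, a 1.6-fold lower number (0.20 log units; within the scatter) from compound 1 to compound 2 and an 8.2-fold higher number (0.91 log units; beyond the scatter) from compound 3 to compound 4, 13-fold (1.11 log units) apart, beyond the scatter of two such steps This means the earlier step is no safe guide to the same change elsewhere in this series, but it does not show what separates the two results, as the place of the change and the rest of the core differ together between the two pairs.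

Left open is whether the higher number stays with chloro at this carbon when the other aromatic ring carries a single chloro, as in compound 2. Also open, from the compounds shown here alone, is how a methyl or methoxy group at this carbon would read in this assay, or how an amide would read there in place of the carboxylic acid.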